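A few compounds are considered here, and "the series" means these few. Any claim that something is new, unique, unknown or untested is made for them only; others in the source may bear on it.

Compound 1 `CC1(C)OC2O[C@@H](Cc3cn4cc(Cl)ccc4nc3=O)C(OCc3ccccc3)C2O1` and compound 2 `O=c1nc2ccc(Cl)cn2cc1Cc1ccc(F)cc1C(F)(F)F` were both tested in a functional assay on HepG2 cells (Homo sapiens) for cytotoxicity, read by MTT assay, with a stated time of 24 h; on this read-out higher numbers stand for weaker inhibition and lower numbers for stronger inhibition. In this assay compound 1 gives > 1000000 nM, which is a limit of the assay rather than a number. In this assay compound 2 likewise gives > 1000000 nM, again a limit and not a number. Compound 1 and compound 2 therefore both sit at the limit of > 1000000 nM in this assay, at which 2 of the 2 values shown sit. Compound 3 `O=c1nc2ccccn2cc1Cc1ccc(F)cc1C(F)(F)F` differs from compound 2 by hydrogen in place of chloro on an aromatic carbon. Among the compounds with values here, with no measured step between compounds to build on, the step of a number no higher from compound 2 to compound 3 (the limit leaves the size open) is expected to stay within the scatter. Compound 3 is estimated at 1000000 nM, between 300000 nM and 3000000 nM, and most likely again reported only as a limit.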

Compound 3, half-maximal inhibitory concentration: 804000 nM
Estimate against measurement, compound 3: 1.2-fold (0.09 log units) above, and the stated range covers the measured number.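

In this assay, within the data shown here, compound 3 gives 804000 nM, the first actual number here rather than a limit. Hydrogen in place of chloro on this aromatic carbon gives an at least 1.2-fold lower number from compound 2 to compound 3 (0.09 log units; that floor lies within the scatter), so a high number does not depend on the chloro. The true size of this step stays unknown because compound 2 has only a limit: the limit of > 1000000 nM in this assay, at which 2 of the 3 values shown sit.

On these data alone, whether a methoxy group, an amine or a nitrile on this aromatic carbon would give a step beyond the scatter remains open.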